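This account rests on a few compounds, and the source may have more. Where it says the series, first, only, none or still open, it means among the compounds named here.

Measured in a functional assay on MCF7 cells (Homo sapiens) for antiproliferative activity, read by sulforhodamine B assay, with a stated time of 48 h; a lower number here means a stronger inhibitor, a higher number a weaker inhibitor:
compound 1 `COc1ccc(/C=C/C(=O)c2ccccc2-c2cccc(F)c2)cc1` gives 640 nM
compound 2 `COc1ccc(/C=C/C(=O)c2ccccc2-c2ccc(F)nc2)cc1` gives 2700 nM
compound 3 `COc1ccc(/C=C/C(=O)c2ccccc2-c2cccc(F)c2)cc1OC` gives 1200 nM

Compound 4 `COc1ccc(/C=C/C(=O)c2ccccc2-c2ccc(F)nc2)cc1OC` has not yet been measured. Compound 1 becomes compound 2 through one change, (6-fluoropyridin-3-yl in place of 3-fluorophenyl on an aromatic carbon), and that change brought a 4.2-fold higher number from compound 1 to compound 2 (0.63 log units; beyond the scatter). Compound 3 becomes compound 4 through the same change, (6-fluoropyridin-3-yl in place of 3-fluorophenyl on an aromatic carbon), at a place described in the same words. The two cores differ by methoxy in place of hydrogen on an aromatic carbon, a step of a 1.9-fold higher number from compound 1 to compound 3 (0.27 log units; within the scatter), which stays within the scatter, so compounds 1 and 3 read much alike. Because the earlier step of a 4.2-fold higher number from compound 1 to compound 2 (0.63 log units; beyond the scatter) was modest and the surroundings of the change match, a comparable step is expected from compound 3 to compound 4, a 4.2-fold higher number from compound 3 to compound 4 (0.62 log units; beyond the scatter). Within the data shown here, with only one prior example, the range is kept wide. Compound 4 is therefore estimated at 5000 nM in this assay, between 2500 nM and 10000 nM.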

Compound 4, half-maximal inhibitory concentration: 2800 nM
The estimate for compound 4 lay 1.8-fold (0.25 log units) above the measured number; the range from low to high includes it.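

In this assay, putting 6-fluoropyridin-3-yl in place of 3-fluorophenyl on the methoxy-bearing core of compound 3 gave a 2.3-fold higher number from compound 3 to compound 4 (0.37 log units; beyond the scatter), and this step agrees with the one seen on the core of compound 1: the same change on two cores in this assay, a 4.2-fold higher number (0.63 log units; beyond the scatter) from compound 1 to compound 2 and a 2.3-fold higher number (0.37 log units; beyond the scatter) from compound 3 to compound 4, 1.8-fold (0.26 log units) apart, within the scatter of two such steps. Methoxy in place of hydrogen gave a 1.0-fold higher number from compound 2 to compound 4 (0.02 log units; within the scatter), so those two compounds read alike, and this step also agrees with its earlier counterpart: the same change on two cores in this assay, a 1.9-fold higher number (0.27 log units; within the scatter) from compound 1 to compound 3 and a 1.0-fold higher number (0.02 log units; within the scatter) from compound 2 to compound 4, 1.8-fold (0.26 log units) apart, within the scatter of two such steps. The change therefore carried across these two cores in direction and, within the scatter, in size, but a single pair of cores cannot show that it would carry to other cores, nor why the number rises.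

The compounds shown leave open how an amine or a carboxylic acid in place of the fluorine would read. They also leave open what an ethoxy group in place of methoxy would do.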